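A Methoxy Group on the Benzoyl of Compound 1

This account rests on a few compounds, and the source may have more. Where it says the series, first, only, none or still open, it means among the compounds named here.

Among the measured compounds shown here, in a functional assay on CHP-134 cells (Homo sapiens) for antiproliferative activity, with a stated time of 72 h (a lower number here means a stronger inhibitor, a higher number a weaker inhibitor), compound 1 `O=C(CCN(Cc1ccc(C(=O)NO)cc1)C(=O)c1ccccc1)NCc1ccccc1` gives 4680 nM, the highest of the three numbers measured so far. Compound 3 `Cc1ccc(NC(=O)CCN(Cc2ccc(C(=O)NO)cc2)C(=O)c2ccccc2)cc1` gives 1160 nM, and compound 2 `Cc1ccc(CNC(=O)CCN(Cc2ccc(C(=O)NO)cc2)C(=O)c2ccc(N(C)C)cc2)cc1` gives 420 nM. Compound 4 `COc1ccc(C(=O)N(CCC(=O)NCc2ccccc2)Cc2ccc(C(=O)NO)cc2)cc1` has not yet been measured. It departs from compound 1 by one change, methoxy in place of hydrogen on an aromatic carbon, para to a large group: methoxy in place of hydrogen on an aromatic carbon.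

For the measured compounds named here, the only measured step, a 4.0-fold lower number from compound 1 to compound 3 (0.61 log units; beyond the scatter), is modest and lies at a different place, on an amide-type nitrogen, so it bears on this change only indirectly. Compound 2 differs from compound 1 in more than one place, and compound 2 with its lower value of 420 nM gives only a weak hint of the direction. Going by the values given here, no measured step isolates a substituent on this aromatic ring. A small move towards a lower number is therefore expected, probably not clearly beyond the scatter. The expected step is a 1.9-fold lower number from compound 1 to compound 4 (0.27 log units; within the scatter). For compound 4 the estimated value is 2500 nM, with an expected range of 900 nM to 6000 nM.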

Compound 4, half-maximal inhibitory concentration: 1900 nM
Compound 4: the middle estimate sits 1.3-fold (0.12 log units) above what was measured; the range from low to high includes it.
By their numbers in this assay, from the lowest: compound 2; then compounds 3 and 4 (each within the scatter of the next); then compound 1.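

Methoxy in place of hydrogen on this aromatic carbon, para to a large group, gives a 2.5-fold lower number from compound 1 to compound 4 (0.39 log units; beyond the scatter) in this assay. Among the compounds shown here, this is the first measured step that isolates a substituent on the benzoyl ring, so a change at this position alone is now seen to lower the number beyond the scatter, though only modestly. The earlier compounds could not show this, since compound 2 differs from compound 1 in more than one place, and nothing measured on these compounds gives a reason for the step.

From the compounds shown here alone, whether a smaller group such as fluorine, or a longer one such as ethoxy, would move the number further at this position remains open. So does whether methoxy here would combine with the 4-methylphenyl change seen in compound 3.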